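The source may hold more compounds than are shown below. What is called first, only, known or untested is meant among the compounds shown, and "the series" means these compounds.

In a functional assay on thoracic aorta (Rattus norvegicus, strain Wistar), with a stated time of 15 min (a higher number here means that more compound is needed for the effect, a lower number that less compound is needed), three compounds on a shared core have been measured. Compound 1 (`CC(C)Oc1ccc(Br)cc1C(C)NC(=O)N(C)S(=O)(=O)c1ccccc1`) gives 32100 nM and compound 2 (`CCOc1ccc(Br)cc1C(C)NC(=O)N(C)S(=O)(=O)c1ccc(C)cc1`) gives 28600 nM, while compound 3 (`COc1ccc(Br)cc1C(C)NC(=O)N(C)S(=O)(=O)c1ccc(C)cc1`) gives 19100 nM and so lies within the scatter of both others. Compound 4 (`Cc1ccc(S(=O)(=O)N(C)C(=O)NC(C)c2cc(Br)ccc2OC(C)C)cc1`) goes from methoxy to isopropoxy relative to compound 3, a change counted as isopropyl in place of methyl on an oxygen on an aromatic ring on an oxygen on an aromatic ring. The closest measured step is a 1.5-fold lower number from compound 2 to compound 3 (0.18 log units; within the scatter) and it does not leave the scatter. Compound 1 also carries isopropoxy, though it differs elsewhere too. In this assay no step beyond the scatter is therefore expected, and the estimate means a 1.5-fold higher number from compound 3 to compound 4 (0.18 log units; within the scatter) and nothing larger. Compound 4 is estimated at 29000 nM with 16000 nM to 50000 nM as its expected range.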

Compound 4, half-maximal effective concentration: 34700 nM
For compound 4 the middle estimate is 1.2-fold (0.08 log units) below the measured one; low and high end bracket the measured number.
By their numbers in this assay, from the lowest: compounds 3, 2, 1 and 4 (each within the scatter of the next).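

In this assay, isopropyl in place of methyl on an oxygen on an aromatic ring gives a 1.8-fold higher number from compound 3 to compound 4 (0.26 log units; within the scatter), so methoxy, ethoxy and isopropoxy at this position all stay within the scatter. Adding a methyl to the ethoxy chain gives a 1.2-fold higher number from compound 2 to compound 4 (0.08 log units; within the scatter), and a methyl on an aromatic carbon gives a 1.1-fold higher number from compound 1 to compound 4 (0.03 log units; within the scatter), so neither change leaves the scatter either. No available evidence bears on this result. The compounds shown leave open whether a longer chain such as butyl, or a chain carrying an amine, on that oxygen would move the number beyond the scatter.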